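Swapping the five-membered ring carried on the side chain

The source may hold more compounds than are shown below. What is called first, only, known or untested is meant among the compounds shown, and "the series" means these compounds.

Compound 2 `C/C(=C1/OC(=O)NC1=O)C(c1ccc(-c2ccc3cccc(F)c3c2)[nH]c1=O)C(C)C` gives no number in an ADME assay on microsomes from liver (Homo sapiens) for metabolic stability; a lower number here means that the compound disappears faster, a higher number that the compound lasts longer: compound 2 reaches > 3 h, which is a limit of the assay. Compound 2 is the one sitting at the limit of > 3 h in this assay, at which 1 of the 2 values shown sits. Compound 1 `CCC(/C=C1\OC(=O)NC1=O)(CC)c1ccc(-c2ccc3cccc(C(C)C)c3c2)[nH]c1=O`, the other measured member, gives 0.758 h in this assay. Compound 3 `CC(C)C(/C=C1/C(=O)NC(=O)N1C)c1ccc(-c2ccc3cccc(F)c3c2)[nH]c1=O` differs from compound 2 by a group of 9 heavy atoms (5 carbon, 2 nitrogen, 2 oxygen; one five-membered non-aromatic ring with 2 hetero atoms) in place of a group of 9 heavy atoms (5 carbon, 1 nitrogen, 3 oxygen; one five-membered non-aromatic ring with 2 hetero atoms), on a saturated chain carbon bound to an aromatic carbon and a saturated chain carbon. Going by the values given here, no measured pair isolates this change, so no step beyond the scatter is expected here. Compound 3 is therefore estimated at 3 h, with a range from 1.5 h to 6 h. The expected step is a number no higher from compound 2 to compound 3 (the limit leaves the size open), and a limit may again be reported.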

Compound 3, half-life: > 3 h
Compound 3 ended at the assay's limit; the forecaster's own chance of this, stated with the estimate: 50%; the middle value lies on the limit itself.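

Compound 2 and compound 3 both end at a limit in this assay, so no step can be read between them: the limit of > 3 h in this assay, at which 2 of the 3 values shown sit.

On these data alone, whether exchanging the five-membered ring between compound 2 and compound 3 changes the half-life at all stays open.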